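Aryl exchange on the piperazine nitrogen: pyridin-2-yl analogue

This account rests on a few compounds, and the source may have more. Where it says the series, first, only, none or still open, it means among the compounds named here.

Compound 1 `O=C1c2ccccc2S(=O)(=O)N1CCCCCCN1CCN(c2ccccc2Cl)CC1` gives 459 nM in an ADME assay on HEK293 cells for displacement of a labelled ligand from 5-hydroxytryptamine receptor 6 (Homo sapiens), read by radioligand binding, with a stated time of 1 h (on this read-out higher numbers stand for weaker inhibition and lower numbers for stronger inhibition), and holds the second highest of the three numbers recorded so far. Compound 2 `O=C1c2ccccc2S(=O)(=O)N1CCCCCCN1CCN(c2cccc(C(F)(F)F)c2)CC1` gives 52 nM, and compound 3 `O=C1c2ccccc2S(=O)(=O)N1CCCCCCN1CCN(c2cccc3cccnc23)CC1` gives 1720 nM. Every change made so far sits on the same amine nitrogen in a ring, and the outcomes diverge: an 8.8-fold lower number from compound 1 to compound 2 (0.95 log units; beyond the scatter), whereas a 3.7-fold higher number from compound 1 to compound 3 (0.57 log units; beyond the scatter), and across the two new aryl groups a 33-fold higher number from compound 2 to compound 3 (1.52 log units; beyond the scatter).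

Compound 4 `O=C1c2ccccc2S(=O)(=O)N1CCCCCCN1CCN(c2ccccn2)CC1` continues this exchange: pyridin-2-yl in place of 2-chlorophenyl on an amine nitrogen in a ring. Both steps out of compound 1 bear on it in that they swap the same group, but neither is a close parallel, and they point in opposite directions, so the series gives no clean direction for a pyridin-2-yl group. What it does show is that this position moves the read-out beyond the scatter in either direction. A modest shift is expected for compound 4, a 1.7-fold higher number from compound 1 to compound 4 (0.24 log units; within the scatter), taken as more likely towards the weaker side seen with compound 3 than towards the gain seen with compound 2. Compound 4 is therefore estimated at 800 nM, with a range from 200 nM to 3500 nM.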

Compound 4, inhibition constant: 2350 nM
Compound 4: middle estimate off by 2.9-fold (0.47 log units), on the low side, within the range that was stated.
By their numbers in this assay, from the lowest: compound 2; then compound 1; then compounds 3 and 4 (each within the scatter of the next).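

In this assay, a second aryl group with a ring nitrogen gives a 5.1-fold higher number from compound 1 to compound 4 (0.71 log units; beyond the scatter) and so joins compound 3 on the weaker side of compound 1, while the gain remains confined to compound 2. The smaller pyridin-2-yl group and the quinolin-8-yl group are not separated, with a 1.4-fold higher number from compound 3 to compound 4 (0.14 log units; within the scatter) and hence no distinction between them on this read-out, whereas a 45-fold higher number from compound 2 to compound 4 (1.66 log units; beyond the scatter) is the widest gap yet at this position. No measurement available here accounts for these differences.

The compounds shown leave open whether the low number of compound 2 is specific to 3-(trifluoromethyl)phenyl or would also appear with 3-chlorophenyl or unsubstituted phenyl. A pyridin-3-yl group would test whether the drop seen with pyridin-2-yl persists when the ring nitrogen is placed differently.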